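Swapping an Acid-Bearing Benzyl Group for a Fluorophenylethyl Group

The compounds below may be only part of what the source reports. "The series", "measured", "known", "first", "only" and "open" are said of these compounds alone.

Measured so far:
- compound 1 `Cc1ccc2cc(CN(Cc3ccc(C(C)C)cc3)Cc3ccccc3F)c(=O)[nH]c2c1`: > 33000 nM
- compound 2 `Cc1ccc2[nH]c(=O)c(CN(Cc3ccc(OCC(=O)O)cc3)Cc3ccc(C(C)(C)C)cc3)cc2c1`: > 10000 nM

Of the compounds shown here, two sharing one core have been tested in a toxicity assay on MDCK cells (Canis lupus familiaris) for cytotoxicity, read by crystal violet staining, with a stated time of 48 h; on this read-out higher numbers stand for lower toxicity in this test and lower numbers for higher toxicity in this test. Compound 1 `Cc1ccc2cc(CN(Cc3ccc(C(C)C)cc3)Cc3ccccc3F)c(=O)[nH]c2c1` gives > 33000 nM, which is a limit of the assay rather than a number; this is the limit of > 33000 nM in this assay, at which 1 of the 2 values shown sits. Compound 2 `Cc1ccc2[nH]c(=O)c(CN(Cc3ccc(OCC(=O)O)cc3)Cc3ccc(C(C)(C)C)cc3)cc2c1` gives > 10000 nM, again a limit of the assay and not a number, as shown by the limit of > 10000 nM in this assay, at which 1 of the 2 values shown sits. So compound 2 stands at one of the two limits recorded here, and nothing more precise is known about how toxic it is.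

The next compound, compound 3 `Cc1ccc2[nH]c(=O)c(CN(Cc3ccc(C(C)(C)C)cc3)C(C)c3ccc(F)cc3)cc2c1`, is not yet measured in this assay. It differs from compound 2 in one place: 1-(4-fluorophenyl)ethyl in place of 4-(carboxymethoxy)benzyl on an amine nitrogen. No step between two measured compounds is available, so the size of this change cannot be read from the numbers shown. With both known values sitting at limits, the expectation is that compound 3 also shows low toxicity, with a step that is expected to be a step that the limit leaves unreadable from compound 2 to compound 3, not clearly beyond the scatter in either direction. Compound 3 is therefore estimated at 20000 nM, in a range from 5000 nM to 60000 nM.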

Compound 3, half-maximal cytotoxic concentration: > 33000 nM
Compound 3 ended at the assay's limit (the forecaster's own chance of this, stated with the estimate: 60%); middle value at least 1.6-fold (0.21 log units) from the limit.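

Going by these compounds alone, compound 2 and compound 3 both end at limits of this assay, not at numbers, and no step between them can be read. The compounds shown leave open how toxic any of them actually is to these cells, and whether 1-(4-fluorophenyl)ethyl in place of 4-(carboxymethoxy)benzyl on an amine nitrogen changes that toxicity at all.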